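The source may hold more compounds than are shown below. What is called first, only, known or untested is meant among the compounds shown, and "the series" means these compounds.

Measured in a functional assay on HUVEC cells (Homo sapiens) for antiproliferative activity, read by MTT assay, with a stated time of 48 h; a higher number here means a weaker inhibitor, a lower number a stronger inhibitor:
compound 1 `O=[N+]([O-])c1ccccc1/C=C/c1nnc(-c2ccc3c(c2)OCCO3)o1`: 25000 nM
compound 2 `Cc1ccc(/C=C/c2nnc(-c3ccc4c(c3)OCCO4)o2)cc1`: 45200 nM
compound 3 `O=[N+]([O-])c1ccc(/C=C/c2nnc(-c3ccc4c(c3)OCCO4)o2)cc1`: 32100 nM

In this assay compound 1 gives 25000 nM, and that value lies within the usual scatter of the values for compound 2 and compound 3. These three compounds therefore cannot be ranked, and compound 1 is best read as one member of a tight group.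

The next compound, compound 4 `Fc1ccccc1/C=C/c1nnc(-c2ccc3c(c2)OCCO3)o1`, keeps the core of compound 1 and has fluoro in place of nitro on an aromatic carbon, ortho to a large group: fluoro in place of nitro on an aromatic carbon.

Going by the values given here, no measured step makes this exact change. The closest evidence is another swap of one group for another on an aromatic carbon, nitro in place of methyl, which gave a 1.4-fold lower number from compound 2 to compound 3 (0.15 log units; within the scatter). Among the compounds with values here, that step stays within the scatter, so it offers no reason to expect a real shift in either direction, although it is only a single example.

The estimated change is a 1.2-fold higher number from compound 1 to compound 4 (0.08 log units; within the scatter), which means no expected step beyond the scatter. For compound 4 the expected value is 30000 nM, with an estimated range of 14000 nM to 62000 nM.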

Compound 4, half-maximal inhibitory concentration: 1160 nM
Beside the measured number, compound 4's estimate is 26-fold (1.41 log units) above it, outside the stated range (below it).
By their numbers in this assay, from the lowest: compound 4; then compounds 1, 3 and 2 (each within the scatter of the next).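

In this assay, going by these compounds alone, this place on the aromatic ring, ortho to a large group, proves highly sensitive to what sits on it: fluoro in place of nitro gives a 22-fold lower number from compound 1 to compound 4 (1.33 log units; beyond the scatter) and is the first single-group swap here to go beyond the scatter. Moving from 4-methylphenyl to 2-fluorophenyl gives a 39-fold lower number from compound 2 to compound 4 (1.59 log units; beyond the scatter) as well, but that step alters both the group and its place on the ring, so it cannot separate the two changes. Nothing measured here explains why this swap has so large an effect.

Going by these compounds, it remains open whether chloro or methoxy at this same place would also give a low number. Also open, on these data alone, is whether fluoro would have a similar effect at the place held by nitro in compound 3.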